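The compounds below may be only part of what the source reports. "The series", "measured", "known", "first", "only" and "open" are said of these compounds alone.

In a functional assay on HT-1080 cells (Homo sapiens) for cytotoxicity, read by MTT assay, with a stated time of 72 h (a lower number here means a stronger inhibitor, a higher number a weaker inhibitor), compound 1 (`COc1cccc(/C=C2\CCC/C(=C\c3ccc(Cl)cc3)C2=O)c1OC`) gives 11100 nM and compound 2 (`COc1cccc(/C=C2\CCC/C(=C\c3ccc(Cl)c(Cl)c3)C2=O)c1OC`) gives 10800 nM so compound 2 stands level with compound 1 within the scatter. Compound 3 (`COc1cccc(/C=C2\CCC/C(=C\c3ccc(O)c(Cl)c3)C2=O)c1OC`) carries hydroxy in place of chloro on an aromatic carbon. Going by the values given here, the only measured step that bears on this is chloro in place of hydrogen (a 1.0-fold lower number from compound 1 to compound 2 (0.01 log units; within the scatter)), which lies within the scatter and does not remove the chloro that leaves here. Among the compounds with values here, no measured compound carries hydroxy, so the expectation is loose. In this assay the expected change is no more than the scatter (a 1.2-fold lower number from compound 2 to compound 3 (0.08 log units; within the scatter)). Compound 3 is estimated at 9000 nM (range 3500 nM to 20000 nM).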

Compound 3, half-maximal inhibitory concentration: 14300 nM
Compound 3: middle estimate off by 1.6-fold (0.20 log units), on the low side; low and high end bracket the measured number.
By their numbers in this assay, from the lowest: compounds 2, 1 and 3 (each within the scatter of the next).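

Going by these compounds alone, the earlier step left the chloro at this place untouched, so this is the first change of the group that sits ortho to a chloro group and para to a large group. In this assay, the swap to hydroxy, which brings a hydrogen-bond donor, gives a 1.3-fold higher number from compound 2 to compound 3 (0.12 log units; within the scatter), and the whole change to 3-chloro-4-hydroxyphenyl gives a 1.3-fold higher number from compound 1 to compound 3 (0.11 log units; within the scatter), so neither step moves the number beyond the scatter. Nothing at hand offers an explanation for this.

From the compounds shown here alone, it remains open whether an amine or a carboxylic acid at this place would behave the same way.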